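Cell tolerance of the phenol analogue compound 4

The source may hold more compounds than are shown below. What is called first, only, known or untested is meant among the compounds shown, and "the series" means these compounds.

Compound 1 `O=C(Nc1cccc(-n2cc(-c3ccncc3)c(-c3ccc(Cl)c(O)c3)n2)c1)Nc1cccc(C(F)(F)F)c1`, compound 2 `COc1cc(-c2nn(-c3cccc(NC(=O)Nc4cccc(C(F)(F)F)c4)c3)cc2-c2ccncc2)ccc1Cl` and compound 3 `COc1cc(-c2nn(-c3cccc(NC(=O)Nc4ccc(Cl)c(C(F)(F)F)c4)c3)cc2-c2ccncc2)ccc1Cl` share one core and differ only in the small changes told below. In a functional assay on 786-0 cells (Homo sapiens) for inhibition, read by sulforhodamine B assay, with a stated time of 48 h (a higher number here means that more compound is tolerated, a lower number that less compound is tolerated), compound 2 gives > 50000 nM, which is a limit of the assay and not a number. Compound 1 gives > 32500 nM in this assay, again a limit. Compound 3 gives > 32500 nM, also a limit. The change hydrogen in place of methyl on an oxygen on an aromatic ring gives a step that the two limits leave unreadable from compound 2 to compound 1, and the change chloro in place of hydrogen on an aromatic carbon gives a step that the two limits leave unreadable from compound 2 to compound 3. Both steps run from the limit of > 50000 nM in this assay, at which 1 of the 3 values shown sits, to the limit of > 32500 nM in this assay, at which 2 of the 3 values shown sit, so neither has a readable size.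

Compound 4 `O=C(Nc1cccc(-n2cc(-c3ccncc3)c(-c3ccc(Cl)c(O)c3)n2)c1)Nc1ccc(Cl)c(C(F)(F)F)c1` is not yet measured. It differs from compound 3 by hydrogen in place of methyl on an oxygen on an aromatic ring, the same change as that made from compound 2 to compound 1, at a place described in the same words. The two cores differ by chloro in place of hydrogen on an aromatic carbon. For compound 4 the expected step in this assay is a step that the limit leaves unreadable from compound 3 to compound 4, set beside a step that the two limits leave unreadable from compound 2 to compound 1; this rests on (the limit of > 32500 nM in this assay, at which 2 of the 3 values shown sit), where compound 1 and compound 3 both sit, and on the earlier step having no readable size. Compound 4 is expected to give about 40000 nM in this assay, with a likely range from 15000 nM to 100000 nM, and most probably only a limit will be reported again.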

Compound 4, concentration lethal to 50% of the cells: > 32500 nM
Compound 4 ended at the assay's limit (the forecaster's own chance of this, stated with the estimate: 80%); the middle value lies beyond the limit too.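

In this assay compound 4 gives > 32500 nM, a limit of the assay and not a number. The steps to compound 4 from compound 3 and from compound 1 therefore cannot be read, with limits at both ends of each. The compounds shown leave open whether methoxy to hydroxy, or chloro in place of hydrogen, changes the tolerated concentration at all, as none of the four gives a number.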